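Notes on the imidazoline series at the alpha-1D receptor

The source may hold more compounds than are shown below. What is called first, only, known or untested is meant among the compounds shown, and "the series" means these compounds.

Measured compounds:
compound 1, `CS(=O)(=O)c1ccc(F)cc1NCC1=NCCN1`, 2630 nM
compound 2, `CSc1ccc(F)cc1NCC1=NCCN1`, 6.17 nM
compound 3, `CSc1c(F)cccc1NCC1=NCCN1`, 302 nM

In an assay for binding affinity to Alpha-1D adrenergic receptor (Homo sapiens), read by radioligand binding (on this read-out lower numbers stand for stronger inhibition and higher numbers for weaker inhibition), compound 1 gives the highest number of the three; compound 3 sits nearer to it, compound 2 far lower. Among the compounds with values here, the one single-point step recorded, a 430-fold lower number from compound 1 to compound 2 (2.63 log units; beyond the scatter), concerns the methylsulfonyl group, which compound 4 keeps unchanged. Compound 4, `CS(=O)(=O)c1ccc(C(F)(F)F)cc1NCC1=NCCN1`, differs from compound 1 only in the change (trifluoromethyl in place of fluoro on an aromatic carbon), the new group sitting para to a methylsulfonyl group and meta to a group of 7 heavy atoms.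

Within the data shown here, no measured pair in the set exchanges fluoro for trifluoromethyl, and compounds 1 and 3, which carry the fluoro at different positions, have no step recorded between them; their two values simply show a gap. Among the measured compounds shown here, the data therefore give no precedent for this change, and in this assay compound 4 is expected to stay close to compound 1, the step of a 1.1-fold lower number from compound 1 to compound 4 (0.02 log units; within the scatter) being expected to fall within or near the scatter, with wide uncertainty. The estimate for compound 4 is 2500 nM, expected between 700 nM and 9000 nM.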

Compound 4, inhibition constant: < 15900 nM
Compound 4 gave a limit, no number (the forecaster's own chance of this, stated with the estimate: 10%); the middle value does not contradict the limit.
By their numbers in this assay, from the lowest: compound 2; then compound 3; then compound 1.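

In this assay compound 4 gives < 15900 nM, which is a limit and not a number. Within the data shown here, no step from compound 1 to compound 4 can be read from it. The compounds shown leave open how trifluoromethyl in place of fluoro shifts the value of compound 1.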